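This account rests on a few compounds, and the source may have more. Where it says the series, first, only, none or still open, it means among the compounds named here.

Series notes. Compound 1 `CC(C)CCNC(=O)C(C)NC(=O)C(Cc1ccccc1)C[C@H](O)[C@H](CC(C)C)NC(=O)C(NC(=O)CC(C)C)C(C)C` gives 2.5 nM in an assay on isolated protein for inhibition of Pepsin A (Sus scrofa); on this read-out higher numbers stand for weaker inhibition and lower numbers for stronger inhibition. Compound 2 `CC(C)CC(=O)NC(C(=O)N[C@@H](CC(C)C)[C@@H](O)CC(C)C(=O)NCC(=O)NC(=O)C(C)C)C(C)C` gives 53 nM in this assay, and compound 3 `CC(C)CC(=O)NC(C(=O)N[C@@H](CC(C)C)[C@@H](O)CC(C)C(=O)NC(C)C(=O)NC(=O)C(C)C)C(C)C` gives 3 nM in this assay, the second highest of the three numbers, close to compound 1 and well apart from compound 2. For the measured compounds named here, the only measured step, an 18-fold lower number from compound 2 to compound 3 (1.25 log units; beyond the scatter), concerns another position and does not bear on the change now considered. Compound 4 `CC(C)CCNC(=O)C(C)NC(=O)C(C)C[C@H](O)[C@H](CC(C)C)NC(=O)C(NC(=O)CC(C)C)C(C)C` differs from compound 3 by isopentyl in place of isopropylcarbonyl on an amide-type nitrogen. Going by the values given here, no measured pair isolates this exchange; compound 1 carries the same isopentyl group and its value stands near that of compound 3. The step is therefore expected to stay within the scatter, a 1.7-fold higher number from compound 3 to compound 4 (0.22 log units; within the scatter). For compound 4 the estimate in this assay is 5 nM, with a range from 1.5 nM to 20 nM.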

Compound 4, inhibition constant: 3 nM
Compound 4: middle estimate off by 1.7-fold (0.22 log units), on the high side, and the stated range covers the measured number.
By their numbers in this assay, from the lowest: compounds 1, 3 and 4 (each within the scatter of the next); then compound 2.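

In this assay, isopentyl in place of isopropylcarbonyl on an amide-type nitrogen gives no change at the digits printed from compound 3 to compound 4 (within the scatter), so the carbonyl of isopropylcarbonyl is not required at this position for a low number. The combined exchange gives an 18-fold lower number from compound 2 to compound 4 (1.25 log units; beyond the scatter) and remains large with isopentyl in place. Removing phenyl from the saturated chain carbon gives a 1.2-fold higher number from compound 1 to compound 4 (0.08 log units; within the scatter), so phenyl is not required there either.

No evidence on the cause of these steps is available. On these data alone, whether a longer chain, an amine or a carboxylic acid on this nitrogen would keep the number remains open.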